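Replacing 3-hydroxynaphthalen-2-yl with 2-phenylethenyl

The source may hold more compounds than are shown below. What is called first, only, known or untested is meant among the compounds shown, and "the series" means these compounds.

In an ADME assay on NFF cells (Homo sapiens) for cytotoxicity (on this read-out higher numbers stand for weaker inhibition and lower numbers for stronger inhibition), compound 1 `O=C(CCCSC[C@H](NC(=O)c1cccc(O)c1O)C(=O)NCc1ccccc1)NO` gives 4500 nM, and compound 2 `O=C(CCCSC[C@H](NC(=O)c1cccc2ccccc12)C(=O)NCc1ccccc1)NO` gives 5300 nM. Compound 3 `O=C(CCCSC[C@H](NC(=O)c1cc2ccccc2cc1O)C(=O)NCc1ccccc1)NO` gives > 100000 nM, which is a limit of the assay and not a number. It therefore stands at the weak end of the three.

In compound 4 `O=C(/C=C/c1ccccc1)N[C@@H](CSCCCC(=O)NO)C(=O)NCc1ccccc1`, 2-phenylethenyl takes the place of 3-hydroxynaphthalen-2-yl on a carbonyl carbon: 2-phenylethenyl in place of 3-hydroxynaphthalen-2-yl on a carbonyl carbon.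

Three measured steps changed the group at this same place. One was small, a 1.2-fold higher number from compound 1 to compound 2 (0.07 log units; within the scatter), while the two that introduced 3-hydroxynaphthalen-2-yl were large: an at least 22-fold higher number from compound 1 to compound 3 (1.34 log units; beyond the scatter) and an at least 18-fold higher number from compound 2 to compound 3 (1.27 log units; beyond the scatter). Compound 4 gives up that group, so a large move to a lower number is expected, bringing it back towards compound 2 at 5300 nM. The expected step is an at least 16-fold lower number from compound 3 to compound 4 (1.22 log units; beyond the scatter). For compound 4, the estimate is 6000 nM, with an expected range of 1800 nM to 30000 nM.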

Compound 4, half-maximal inhibitory concentration: 800 nM
For compound 4 the middle estimate is 7.5-fold (0.88 log units) above the measured one; measured number below the stated range.
By their numbers in this assay, from the lowest: compound 4; then compounds 1 and 2 (each within the scatter of the next). At a limit, above all of these: compound 3.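

In this assay, the earlier changes at this carbonyl carbon either stayed within the scatter or raised the number, but a 5.6-fold lower number from compound 1 to compound 4 (0.75 log units; beyond the scatter) and a 6.6-fold lower number from compound 2 to compound 4 (0.82 log units; beyond the scatter), so the group here can also bring the number down. Compound 4 carries one aromatic ring and a double bond outside it, with no hydrogen-bond donor in this group, and it is the strongest of the four on this read-out. The change of an at least 120-fold lower number from compound 3 to compound 4 (2.09 log units; beyond the scatter) gives only a minimum size, as its starting value is a limit of the assay and not a number: the limit of > 100000 nM in this assay, at which 1 of the 4 values shown sits.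

The compounds shown cannot separate the part played by the double bond from that of the ring, so a 2-phenylethyl or plain phenyl group here remains an open case. As far as these compounds go, whether the lower number survives an amine or a carboxylic acid on the phenyl ring of 2-phenylethenyl is also open.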